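Swapping Bromine for Chlorine on a Phenoxy Ring

The compounds below may be only part of what the source reports. "The series", "measured", "known", "first", "only" and "open" are said of these compounds alone.

Compound 2 `Brc1ccc(Oc2ccc(/C=N/Nc3nc4ccccc4s3)cc2)cc1` gives 5.5 in a physicochemical assay for lipophilicity, in phosphate buffer, measured as octanol-water partition, with a stated time of 24 h; on this read-out higher numbers stand for higher lipophilicity and lower numbers for lower lipophilicity. Compound 1 `O=C(CSc1nc2ccccc2s1)N/N=C/c1ccc(Oc2ccccc2)cc1` gives 5.6, and the two numbers lie within the scatter of each other. Compound 3 `O=C(CSc1nc2ccccc2s1)N/N=C/c1ccc(Oc2ccc3ccccc3c2)cc1` gives 5.9 and stands higher than compound 2, beyond the scatter. Within the data shown here, the one measured step, a number 0.30 log units higher from compound 1 to compound 3 (within the scatter), concerns a different part of the molecule and does not speak to the change at hand. Compound 4 `Clc1ccc(Oc2ccc(/C=N/Nc3nc4ccccc4s3)cc2)cc1` differs from compound 2 by chloro in place of bromo on an aromatic carbon. Among the measured compounds shown here, no measured step in this set matches that exchange, so the expectation rests on the exchange alone, one heavy atom for one heavy atom. A small drop, a number 0.20 log units lower from compound 2 to compound 4 (within the scatter), is expected. Compound 4 is estimated at 5.3, with a range from 5 to 5.6.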

Compound 4, partition coefficient: 5.6
Compound 4: the middle estimate sits 0.30 log units below what was measured; the measured number falls inside the stated range.
By their numbers in this assay, from the lowest: compounds 2, 1, 4 and 3 (each within the scatter of the next, the first and the last beyond it).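

In this assay, the exchange of 4-bromophenoxy to 4-chlorophenoxy gives a number 0.10 log units higher from compound 2 to compound 4 (within the scatter), so this one pair does not separate the two halogens at this position. The earlier compounds shown here offered no such comparison at this place. No supporting measurement bears on this result.

Going by these compounds, whether an amine, a carboxylic acid or a longer chain at the same position would also stay within the scatter of compound 2 remains open. So does whether a fluoro group would read like chloro and bromo here.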